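Carboxymethyl for ethyl on the shared core

The source may report more compounds than this note shows. Statements on the series, on what has been measured and on what is new or still open speak of the compounds shown alone.

The series is followed in a functional assay for inhibition, with Homo sapiens as the target; a lower number here means a stronger inhibitor, a higher number a weaker inhibitor. Compound 1 `CCCc1nc(C)c2c(C)nn(CC)c(=O)n12` is the reference point. In this assay compound 1 gives > 48000 nM, which is a limit rather than a number. Compound 2 `Cc1nnc(S)n2cncc12` belongs to the same set. In this assay compound 2 gives > 48000 nM, again a limit. Where compound 1 stands is set only by the limit of > 48000 nM in this assay, at which 2 of the 2 values shown sit; no measured number places it, and the one further value is a limit too. Going by the values given here, no step between measured compounds is available.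

Compound 3 `CCCc1nc(C)c2c(C)nn(CC(=O)O)c(=O)n12` differs from compound 1 by carboxy in place of methyl on a saturated chain carbon bound to an aromatic nitrogen, in words carboxy in place of methyl on a saturated chain carbon bound to an aromatic nitrogen. With compound 1 at a limit, no step beyond the scatter is expected in either direction, and compound 3 is expected to stay at the limit. The step implied by this estimate is a step that the limit leaves unreadable from compound 1 to compound 3, expected to lie within the scatter. For compound 3 the estimate is 60000 nM, with a range from 20000 nM to 200000 nM.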

Compound 3, half-maximal inhibitory concentration: > 48000 nM
Compound 3: only a limit was reported; the forecaster's own chance of this, stated with the estimate: 85%; the middle value is on the limit's open side.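

Carboxymethyl for ethyl gives no readable step between compound 1 and compound 3 in this assay, since both stand only at a limit: the limit of > 48000 nM in this assay, at which 3 of the 3 values shown sit.

The compounds shown leave open how strongly any of them inhibits, and whether ethyl or carboxymethyl on the shared core makes any difference.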